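The compounds below may be only part of what the source reports. "The series", "measured", "known", "first", "only" and "open" are said of these compounds alone.

Measured in an ADME assay on the whole organism (Mus musculus, strain CD1) for pharmacokinetics, read by LC-MS, with a stated time of 24 h, at a dose of 1 mg/kg by the intravenous route; on this read-out lower numbers stand for slow clearance and higher numbers for fast clearance:
Compound 1 `O=C(O)Cn1nc(Cc2nc3cc(Cl)c(OCC(F)F)cc3[nH]2)c2ccccc2c1=O` gives 51.7 mL/min/kg
Compound 2 `O=C(O)Cc1nn(Cc2cn3cc(OCC4CC4)c(Cl)cc3n2)c2ccccc2c1=O` gives 11.7 mL/min/kg
Compound 3 `CC(C(=O)O)c1nn(Cc2cn3cc(OCC4CC4)c(C(F)(F)F)cc3n2)c2ccccc2c1=O` gives 4.17 mL/min/kg

Compound 2 stands second highest of the three, with compound 3 lower and compound 1 higher, and both gaps lie beyond the usual scatter. Compound 4 `CCC(C(=O)O)c1nn(Cc2cn3cc(OCC4CC4)c(Cl)cc3n2)c2ccccc2c1=O` departs from compound 2 in one place (ethyl in place of hydrogen on a saturated chain carbon bound to an aromatic carbon and a carbonyl carbon), with ethyl in place of hydrogen on a saturated chain carbon bound to an aromatic carbon and a carbonyl carbon. The carboxymethyl group thus becomes 1-carboxypropyl. Among the compounds with values here, no pair of measured compounds isolates this change. The nearest guide is compound 3 (4.17 mL/min/kg), which also has a branched acid chain but differs from compound 2 elsewhere as well, so it offers only a weak hint. A modest fall in clearance is expected, probably not beyond the scatter, and the expected step is a 1.7-fold lower number from compound 2 to compound 4 (0.22 log units; within the scatter) in this assay terms. For compound 4 the estimated clearance is 7 mL/min/kg within an expected range of 3 mL/min/kg to 16 mL/min/kg when measured.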

Compound 4, clearance in the Mus musculus assay: 12 mL/min/kg
For compound 4 the middle estimate is 1.7-fold (0.23 log units) below the measured one, within the range that was stated.
By their numbers in the Mus musculus assay, from the lowest: compound 3; then compounds 2 and 4 (each within the scatter of the next); then compound 1.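

Within the data shown here, in the Mus musculus assay the change from carboxymethyl to 1-carboxypropyl gives a 1.0-fold higher number from compound 2 to compound 4 (0.01 log units; within the scatter) and so provides the first direct reading at this saturated chain carbon. On this single pair, ethyl in place of hydrogen leaves compound 2 and compound 4 within the scatter of each other on clearance. The same change does separate the pair in a physicochemical assay for solubility, measured as thermodynamic solubility, at pH 7.4; on this read-out lower numbers stand for lower solubility and higher numbers for higher solubility: the measured solubility of compound 2, 919 ug/mL, and of compound 4, 359 ug/mL, a 2.6-fold lower number (0.41 log units; beyond the scatter). In the physicochemical assay compound 2 gives 919 ug/mL and compound 4 gives 359 ug/mL.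

As far as these compounds go, whether a longer chain, such as propyl, or a hydroxyl group on this carbon would also leave clearance within the scatter remains open, as does how either group would read on solubility. The compounds shown also leave open whether ethyl would read the same way on a core carrying trifluoromethyl in place of the chlorine of compound 2 and compound 4.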